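The source may hold more compounds than are shown below. What is called first, only, known or untested is meant among the compounds shown, and "the series" means these compounds.

In a functional assay on A-375 cells (Homo sapiens) for antiproliferative activity, read by MTT assay, with a stated time of 72 h (on this read-out lower numbers stand for stronger inhibition and higher numbers for weaker inhibition), compound 1 `O=C1COc2ccc(-c3cccc(NS(=O)(=O)c4ccc(F)cc4)c3)cc2N1c1ccc(Cl)cc1`, with a 4-chlorophenyl on the amide-type nitrogen in a ring, gives 32500 nM. Compound 2 `O=C1COc2ccc(-c3cccc(NS(=O)(=O)c4ccc(F)cc4)c3)cc2N1c1ccccc1`, with a plain phenyl at that place, reports only a limit, > 40000 nM, and not a number. Compound 3 `O=C1COc2ccc(-c3cccc(NS(=O)(=O)c4ccc(F)cc4)c3)cc2N1C1CCCCC1`, with cyclohexyl there, gives 23800 nM. Going by the values given here, its only exact comparison is a 1.4-fold lower number from compound 1 to compound 3 (0.14 log units; within the scatter), so compound 3 and compound 1 cannot be told apart in this assay.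

Compound 4 `O=C1COc2ccc(-c3cccc(NS(=O)(=O)c4ccc(F)cc4)c3)cc2N1c1ccc(F)cc1` has not yet been measured. It carries 4-fluorophenyl in place of cyclohexyl on an amide-type nitrogen in a ring. Among the compounds with values here, no measured step makes this exact change. The nearest guides are two steps that run the other way, from an aromatic ring to cyclohexyl: a 1.4-fold lower number from compound 1 to compound 3 (0.14 log units; within the scatter) and an at least 1.6-fold lower number from compound 2 to compound 3 (0.22 log units; that floor lies within the scatter). Removing the halogen gives an at least 1.2-fold higher number from compound 1 to compound 2 (0.09 log units; that floor lies within the scatter), so that change offers no clear signal either. Compound 4 therefore most resembles compound 1, which has a different halogen at the same place on the ring. A small move towards a higher number is expected, but nothing beyond the scatter. The estimated step is a 1.4-fold higher number from compound 3 to compound 4 (0.14 log units; within the scatter). For compound 4, the expected value is 33000 nM, with an estimated range from 20000 nM to 50000 nM.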

Compound 4, half-maximal inhibitory concentration: > 40000 nM
Compound 4: only a limit was reported; the forecaster's own chance of this, stated with the estimate: 35%; at least 1.2-fold (0.08 log units) between middle value and limit.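

In this assay, compound 4 reports only a limit, > 40000 nM, and not a number. Going by these compounds alone, the readable steps are an at least 1.6-fold higher number from compound 3 to compound 4 (0.22 log units; that floor lies within the scatter) and an at least 1.2-fold higher number from compound 1 to compound 4 (0.09 log units; that floor lies within the scatter); both floors lie within the scatter, so swapping cyclohexyl for 4-fluorophenyl or chloro for fluoro still gives no step at this position that can be told apart from the scatter, and with a fourth group on the amide-type nitrogen in a ring, no change there has yet produced a clear difference. The step between compound 2 and compound 4 cannot be read, because neither compound has an exact number: the limit of > 40000 nM in this assay, at which 2 of the 4 values shown sit.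

On these data alone, what stays open is whether a group of a different kind on this nitrogen, such as a chain ending in an amine, a carboxylic acid or a longer alkyl chain, would give a number clearly lower than those seen here. The compounds shown also leave open whether this nitrogen matters much at all, since every one of them keeps the rest of the structure unchanged.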